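A Larger Carbamate Ester on a Shared Core

The compounds below may be only part of what the source reports. "The series", "measured", "known", "first", "only" and "open" are said of these compounds alone.

Compound 3 `COC(=O)N1CCC(Oc2ncnc3c2CCN3c2ccc(S(C)(=O)=O)cc2F)CC1` stands at 316 nM in a functional assay on CHO-K1 cells for agonist activity at Glucose-dependent insulinotropic receptor (Homo sapiens), read by a luciferase reporter, with a stated time of 5 h (on this read-out lower numbers stand for an effect already at smaller amounts and higher numbers for an effect only at larger amounts of compound), the highest of the three numbers measured. Compound 1 `CC(C)(C)OC(=O)N1CCC(Oc2cccc3c2CCN3c2ccc(S(C)(=O)=O)cc2)CC1` gives 158 nM there, within the scatter of compound 3, while compound 2 `CC(C)OC(=O)N1CCC(Oc2ncnc3c2CCN3c2ccc(-c3nccs3)cc2F)CC1` gives 79.4 nM, a gap beyond the scatter. Compound 4 `COCCOC(=O)N1CCC(Oc2ncnc3c2CCN3c2ccc(S(C)(=O)=O)cc2F)CC1` differs from compound 3 by methoxymethyl in place of hydrogen on a saturated chain carbon bound to an oxygen next to a carbonyl group, so methoxycarbonyl becomes (2-methoxyethoxy)carbonyl. Going by the values given here, no measured pair shows this change alone; compounds 1 and 2 carry other carbamate esters but also differ from compound 3 elsewhere. Compound 4 is expected to shift only modestly toward a lower number, as a 1.6-fold lower number from compound 3 to compound 4 (0.20 log units; within the scatter), a step likely within the scatter. The estimate for compound 4 in this assay is 200 nM, ranging from 80 nM to 500 nM.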

Compound 4, half-maximal effective concentration: 316 nM
Compound 4: the middle estimate sits 1.6-fold (0.20 log units) below what was measured; measured number inside the range.
By their numbers in this assay, from the lowest: compounds 2, 1, 3 and 4 (each within the scatter of the next, the first and the last beyond it).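

In this assay, going by these compounds alone, the change can now be read alone for the first time: no change at the digits printed from compound 3 to compound 4 (within the scatter), so methoxycarbonyl becoming (2-methoxyethoxy)carbonyl on the shared core leaves the number as it stood. The earlier compounds shown here, which also differ elsewhere, could not show that this position accepts the longer ester without a step beyond the scatter. Nothing at hand offers an explanation for this result.

From the compounds shown here alone, whether an amine or a carboxylic acid at the end of this chain would move the number stays open. So does whether the same change behaves alike on the core of compound 1.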